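Dimethyl groups on the benzoyl arm: expected cytotoxicity

The source may hold more compounds than are shown below. What is called first, only, known or untested is meant among the compounds shown, and "the series" means these compounds.

Compound 2 `Cc1cc(S(N)(=O)=O)ccc1NC(=O)COc1ccc2cc(Br)ccc2c1C(=O)c1ccccc1` stands at the lowest of two numbers in an ADME assay on C8166 cells (Homo sapiens) for cytotoxicity, read by colorimetric assay and MTT assay (on this read-out higher numbers stand for lower toxicity in this test and lower numbers for higher toxicity in this test), where compound 2 gives 29200 nM. Its nearest neighbour is compound 1 `Cc1cc(S(N)(=O)=O)ccc1NC(=O)COc1ccc2ccccc2c1C(=O)c1ccccc1`, and in this assay compound 1 gives 33800 nM. Among the measured compounds shown here, the single measured step, a 1.2-fold lower number from compound 1 to compound 2 (0.06 log units; within the scatter), is within the scatter, so the two compounds are not told apart by this read-out.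

Compound 3 `Cc1ccc(C(=O)c2c(OCC(=O)Nc3ccc(S(N)(=O)=O)cc3C)ccc3cc(Br)ccc23)c(C)c1` differs from compound 2 by 2,4-dimethylphenyl in place of phenyl on a carbonyl carbon. For the measured compounds named here, no measured step touches the carbonyl-bound ring; the bromo step a 1.2-fold lower number from compound 1 to compound 2 (0.06 log units; within the scatter) is the only guide, and it shows that one added group on the shared core left the number where it was. Compound 3 is therefore expected to move by a 1.2-fold lower number from compound 2 to compound 3 (0.07 log units; within the scatter) in this assay, a step not beyond the scatter. The estimate for compound 3 is 25000 nM, between 12000 nM and 55000 nM.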

Compound 3, half-maximal cytotoxic concentration: 61400 nM
Compound 3: the middle estimate sits 2.5-fold (0.39 log units) below what was measured; the measured number lies above the stated range.
By their numbers in this assay, from the lowest: compounds 2, 1 and 3 (each within the scatter of the next, the first and the last beyond it).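

Among the compounds shown here, putting 2,4-dimethylphenyl in place of phenyl on a carbonyl carbon gives a 2.1-fold higher number from compound 2 to compound 3 (0.32 log units; beyond the scatter) in this assay, so this is the first change to move the number beyond the scatter, in the direction of lower toxicity in this test. The bromo step, a 1.2-fold lower number from compound 1 to compound 2 (0.06 log units; within the scatter), stayed within the scatter, which marks the group on the carbonyl carbon as the one place shown here where a change registers in this assay. Nothing available accounts for this rise.

The compounds shown leave open whether a single methyl group on this ring would carry the same step, and whether a ring bearing an amine or a carboxylic acid would move the number alike. They also leave open whether the change holds on the core of compound 1, which lacks the bromo group.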